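Amide nitrogen substituent: aryl to dimethylaminopropyl on the shared core

The source may report more compounds than this note shows. Statements on the series, on what has been measured and on what is new or still open speak of the compounds shown alone.

The series is built on the common core of compound 1 `O=C(O)CCC(=O)OCCCCCCSc1ccc([N+](=O)[O-])c2nonc12` and is followed in an assay on isolated protein for inhibition of glutathione S-transferase P (Homo sapiens), with a stated time of 10 min; a higher number here means a weaker inhibitor, a lower number a stronger inhibitor. In this assay compound 1 gives 530 nM. Compound 2 `COc1ccccc1NC(=O)CCC(=O)OCCCCCCSc1ccc([N+](=O)[O-])c2nonc12` gives 4050 nM, and compound 3 `O=C(CCC(=O)OCCCCCCSc1ccc([N+](=O)[O-])c2nonc12)Nc1ccc(C(F)(F)F)cc1` gives 5050 nM, the highest of the three numbers. The two anilides sit close together: a 1.2-fold higher number from compound 2 to compound 3 (0.10 log units; within the scatter). Both lie apart from the acid, as a 7.6-fold higher number from compound 1 to compound 2 (0.88 log units; beyond the scatter) and a 9.5-fold higher number from compound 1 to compound 3 (0.98 log units; beyond the scatter) show.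

Compound 4 `CN(C)CCCNC(=O)CCC(=O)OCCCCCCSc1ccc([N+](=O)[O-])c2nonc12` differs from compound 3 in one place: 3-(dimethylamino)propyl in place of 4-(trifluoromethyl)phenyl on an amide-type nitrogen. Among the compounds with values here, no measured step replaces an aryl group on this nitrogen with a chain; the only step at this position is the aryl-to-aryl exchange from compound 2 to compound 3, which stayed within the scatter. The acid-to-anilide steps give the size of change seen so far when this end of the molecule is altered, but they change the hydroxy, not the nitrogen substituent.

On this thin basis compound 4 is expected to remain near the amide pair, with an estimated step of a 1.4-fold lower number from compound 3 to compound 4 (0.16 log units; within the scatter) that may or may not exceed the scatter. The estimate for compound 4 in this assay is 3500 nM, with a range of 1200 nM to 10000 nM.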

Compound 4, half-maximal inhibitory concentration: 160 nM
The estimate for compound 4 lay 22-fold (1.34 log units) above the measured number, and the stated range ends above it.
By their numbers in this assay, from the lowest: compound 4; then compound 1; then compounds 2 and 3 (each within the scatter of the next).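

In this assay the substituent on the amide-type nitrogen now proves able to move the number strongly: the exchange of one aryl group for another had stayed within the scatter, yet 3-(dimethylamino)propyl in place of 4-(trifluoromethyl)phenyl gives a large step (a 32-fold lower number from compound 3 to compound 4 (1.50 log units; beyond the scatter)), and the same group in place of 2-methoxyphenyl gives another (a 25-fold lower number from compound 2 to compound 4 (1.40 log units; beyond the scatter)). Amide formation at this end therefore does not in itself bring a higher number than the acid: compounds 2 and 3 go that way, whereas compound 4 goes against it with a modest step in the other direction (a 3.3-fold lower number from compound 1 to compound 4 (0.52 log units; beyond the scatter)). No measured evidence on these compounds bears on what lies behind the shift.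

The compounds shown leave open whether the lower number goes with the terminal dimethylamino group or with the replacement of an aryl group by a chain; a plain butyl chain without an amine would separate these two readings. Also open, as far as these compounds go, is how far the result holds with a shorter or longer chain ending in the same amine, or with a primary amine or a carboxylic acid at the end of the propyl chain.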